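The source may hold more compounds than are shown below. What is called first, only, known or untested is meant among the compounds shown, and "the series" means these compounds.

Compound 1 `CCC(C)C(NC(=O)n1nnc2ccccc21)C(=O)NC1CCCCC1` was tested in a functional assay on HEL cells (Homo sapiens) for cytotoxicity (a lower number here means that less compound is tolerated, a higher number that more compound is tolerated), where compound 1 gives 76 ug/mL. Compound 2 `CCC(C)C1NC(=O)N(Cc2ccccc2)C1=O` gives 50 ug/mL in this assay, so compound 1 holds the higher of the two numbers shown, though the gap lies within the scatter. For compound 3 `CC(C)C1NC(=O)N(C2CCCCC2)C1=O` only a limit is reported in this assay: > 50 ug/mL. That value is the limit of > 50 ug/mL in this assay, at which 1 of the 3 values shown sits. Compound 4 `CCC(C)C(NC(=O)n1nnc2ccccc21)C(=O)NC1CCCC1` has not yet been measured. Going by the values given here, its single difference from compound 1 is cyclopentyl in place of cyclohexyl on an amide-type nitrogen. Among the compounds with values here, no measured pair of compounds shows this change, and no step beyond the scatter is expected in either direction. Compound 4 is therefore estimated at 70 ug/mL, within 35 ug/mL to 150 ug/mL. The step is expected to be a 1.1-fold lower number from compound 1 to compound 4 (0.04 log units; within the scatter).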

Compound 4, half-maximal cytotoxic concentration: 87.3 ug/mL
Compound 4: middle estimate off by 1.2-fold (0.10 log units), on the low side; measured number inside the range.
By their numbers in this assay, from the lowest: compounds 2, 1 and 4 (each within the scatter of the next).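

Putting cyclopentyl in place of cyclohexyl on an amide-type nitrogen gives, in this assay, a 1.1-fold higher number from compound 1 to compound 4 (0.06 log units; within the scatter). Going by these compounds alone, this is the first pair that isolates this position, and it shows that these two ring sizes cannot be told apart here. No measurement shown here bears on why the two rings read alike.

Only these two carbon rings are compared at this nitrogen. As far as these compounds go, it remains open whether a much smaller group such as cyclopropyl, an aromatic phenyl ring, or a cyclohexyl ring carrying an amine would also stay within the scatter.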